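A few compounds are considered here, and "the series" means these few. Any claim that something is new, unique, unknown or untested is made for them only; others in the source may bear on it.

Measured so far in a functional assay on A549 cells (Homo sapiens) for antiproliferative activity, read by MTT assay; on this read-out higher numbers stand for weaker inhibition and lower numbers for stronger inhibition:
compound 1 `O=C1N=C(N2CCC[C@H]2C(=O)Nc2ccc3ncnc(Nc4cccc(Cl)c4)c3c2)S/C1=C/c1cccnc1` gives 10400 nM
compound 2 `O=C1N=C(N2CCC[C@H]2C(=O)Nc2ccc3ncnc(Nc4cccc(Cl)c4)c3c2)S/C1=C/c1cccc(Br)n1` gives 3100 nM
compound 3 `O=C1N=C(N2CCC[C@H]2C(=O)Nc2ccc3ncnc(Nc4cccc(Cl)c4)c3c2)S/C1=C/c1cccnc1Cl` gives 10800 nM

Compound 1 stands second highest of the three numbers; its nearest neighbour is compound 3, within the scatter, its furthest is compound 2, with a 3.4-fold lower number from compound 1 to compound 2 (0.53 log units; beyond the scatter).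

Compound 4 `O=C1N=C(N2CCC[C@H]2C(=O)Nc2ccc3ncnc(Nc4cccc(Cl)c4)c3c2)S/C1=C/c1ccccc1F` differs from compound 1 by 2-fluorophenyl in place of pyridin-3-yl on a double-bonded chain carbon bound to a double-bonded ring carbon. Within the data shown here, no measured step removes the ring nitrogen. Among the measured compounds shown here, two steps bear loosely on it: the aryl exchange a 3.4-fold lower number from compound 1 to compound 2 (0.53 log units; beyond the scatter), and the halogen addition a 1.0-fold higher number from compound 1 to compound 3 (0.02 log units; within the scatter), which stays within the scatter. One aryl exchange gave a modest step, one halogen did nothing, so for compound 4 a step within the scatter, or a small one in either direction, is expected in this assay.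

For compound 4 the estimate is 9000 nM, range 3500 nM to 25000 nM, meaning an expected step of a 1.2-fold lower number from compound 1 to compound 4 (0.06 log units; within the scatter).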

Compound 4, half-maximal inhibitory concentration: 34500 nM
The estimate for compound 4 lay 3.8-fold (0.58 log units) below the measured number, and the stated range ends below it.
By their numbers in this assay, from the lowest: compound 2; then compounds 1 and 3 (each within the scatter of the next); then compound 4.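

In this assay, 2-fluorophenyl on the double-bonded chain carbon gives the highest number of the series, with all three steps beyond the scatter: a 3.3-fold higher number from compound 1 to compound 4 (0.52 log units; beyond the scatter), a 3.2-fold higher number from compound 3 to compound 4 (0.50 log units; beyond the scatter) and an 11-fold higher number from compound 2 to compound 4 (1.05 log units; beyond the scatter). All three pyridine-bearing compounds therefore stand lower than the carbon-only ring, though the exchange removes the ring nitrogen and adds fluoro at once. No measured evidence accounts for this step.

Open, going by these compounds, is which of the two changes carries the step, and where plain phenyl or 2-methoxyphenyl would stand at this place.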